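Bromophenyl for pyridinyl: cytotoxicity of compound 3 expected

A few compounds are considered here, and "the series" means these few. Any claim that something is new, unique, unknown or untested is made for them only; others in the source may bear on it.

Compound 1 `CN1Cc2ccc(OCCc3ccccc3)cc2[C@@H](O)C1` in an ADME assay on Vero cells (Chlorocebus sabaeus) for cytotoxicity, read by sulforhodamine B assay, with a stated time of 72 h (a lower number here means a stronger inhibitor, a higher number a weaker inhibitor), gives > 50000 nM, a limit of the assay.
Compound 2 `CN1Cc2ccc(OCc3cccnc3)cc2[C@@H](O)C1` in this assay gives > 50000 nM, likewise a limit.

Compound 2 therefore stands at the edge of what the assay reports, as does its neighbour, a situation summed up by the limit of > 50000 nM in this assay, at which 2 of the 2 values shown sit. Among the measured compounds shown here, the only measured step, a step that the two limits leave unreadable from compound 1 to compound 2, is unreadable. Compound 3 `CN1Cc2ccc(OCc3cccc(Br)c3)cc2[C@@H](O)C1` differs from compound 2 by 3-bromophenyl in place of pyridin-3-yl on a saturated chain carbon bound to an oxygen on an aromatic ring. No readable step bears on this change, so for compound 3 a step that the limit leaves unreadable from compound 2 to compound 3 is expected, that is none beyond the scatter. Compound 3 is estimated at 60000 nM, within 20000 nM to 200000 nM.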

Compound 3, half-maximal inhibitory concentration: 60300 nM
Estimate against measurement, compound 3: 1.0-fold (0.00 log units) below, within the range that was stated.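

Among the compounds shown here, no step to compound 3 can be read from compound 1 or compound 2, whose results are limits: the limit of > 50000 nM in this assay, at which 2 of the 3 values shown sit. In this assay the compounds shown leave open how far compound 1 and compound 2 lie from compound 3.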